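Trading Trifluoromethyl for Bromo: an Estimate for Compound 4

The source may hold more compounds than are shown below. What is called first, only, known or untested is meant among the compounds shown, and "the series" means these compounds.

Compound 1 `C=C1C[C@]23C[C@@]1(O)CC[C@H]2c1ccc(O)c(C)c1[C@@H]3Cn1cc(-c2ccccn2)nn1`: in a functional assay on MCF7 cells (Homo sapiens) for cytotoxicity, read by MTT assay, with a stated time of 4 days (on this read-out lower numbers stand for stronger inhibition and higher numbers for weaker inhibition), the value > 20000 nM for compound 1 is a limit of the assay, not a number.
Compound 2 `C=C1C[C@]23C[C@@]1(O)CC[C@H]2c1ccc(OS(=O)(=O)c2ccc(C)cc2)c(C)c1[C@@H]3Cn1cc(-c2ccc(Br)cc2)nn1`: for compound 2 the value > 20000 nM is likewise a limit.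
Compound 3 `C=C1C[C@]23C[C@@]1(O)CC[C@H]2c1ccc(O)c(C)c1[C@@H]3Cn1cc(-c2ccc(C(F)(F)F)cc2)nn1`: compound 3 gives 12400 nM.

Among the compounds with values here, compound 3 therefore holds the only actual number of the three; the other two sit at the limit of > 20000 nM in this assay, at which 2 of the 3 values shown sit. Within the data shown here, the one measured step, an at least 1.6-fold lower number from compound 1 to compound 3 (0.20 log units; that floor lies within the scatter), shows how little can be pinned down from these data. Compound 4 `C=C1C[C@]23C[C@@]1(O)CC[C@H]2c1ccc(O)c(C)c1[C@@H]3Cn1cc(-c2ccc(Br)cc2)nn1` differs from compound 3 by bromo in place of trifluoromethyl on an aromatic carbon. Among the measured compounds shown here, no measured step covers that change: compound 2 carries the same 4-bromophenyl but differs from compound 4 in a second place as well, and the step from compound 1 to compound 3 concerns a different ring. Compound 4 is thus expected to show no change beyond the scatter. The estimated step is a 1.2-fold higher number from compound 3 to compound 4 (0.08 log units; within the scatter). For compound 4 the expected value is 15000 nM, within 6000 nM to 40000 nM, with a real chance that only a limit is reported.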

Compound 4, half-maximal inhibitory concentration: > 20000 nM
Compound 4: a limit, no number (the forecaster's own chance of this, stated with the estimate: 40%); middle value at least 1.3-fold (0.12 log units) away from the limit.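

Compound 4 returns a limit rather than a number, so bromo at this position of the phenyl ring gives no measurable value in this assay. Against the trifluoromethyl of compound 3, the change gives an at least 1.6-fold higher number from compound 3 to compound 4 (0.20 log units; that floor lies within the scatter), and since that is only a floor, the data cannot establish a real loss of activity. The steps to compound 4 from compound 1 and from compound 2 cannot be read, because each joins two limits: the limit of > 20000 nM in this assay, at which 3 of the 4 values shown sit.

Going by these compounds, how far the true value of compound 4 lies past its limit remains open, and so does the real size of the step from trifluoromethyl to bromo. The compounds shown also leave open whether an amine or a carboxylic acid in this same place would give a clearly lower number on the shared core.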